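Trading a methoxyphenyl for a difluorophenyl on the chalcone

This account rests on a few compounds, and the source may have more. Where it says the series, first, only, none or still open, it means among the compounds named here.

Compound 1 `COc1ccc(/C=C/C(=O)c2ccc(OCCCSC(=S)N3CCN(C)CC3)cc2)cc1` gives > 100000 nM
Compound 2 `O=C(/C=C/c1cccs1)c1ccc(OCCSC(=S)N2CCCC2)cc1` gives 18300 nM
Compound 3 `COc1cc(/C=C/C(=O)c2ccc(OCCSC(=S)N3CCCCC3)cc2)cc(OC)c1OC` gives 38900 nM

All three were tested in a functional assay on ECa-109 cells for inhibition, with ECa-109 cell line (Homo sapiens) as the target, read by MTT assay, with a stated time of 72 h; a lower number here means a stronger inhibitor, a higher number a weaker inhibitor. In this assay compound 1 reaches only a limit, > 100000 nM, so its true position is not known beyond that. It is the limit of > 100000 nM in this assay, at which 1 of the 3 values shown sits. Among the measured compounds shown here, compound 2 and compound 3 both give numbers, with compound 2 giving 18300 nM and compound 3 giving 38900 nM; no step between them is worked out, since they differ in more than one place, so only the two values themselves can be read. Compound 4 `CN1CCN(C(=S)SCCCOc2ccc(C(=O)/C=C/c3cc(F)cc(F)c3)cc2)CC1` has not been measured. It differs from compound 1 in one place: 3,5-difluorophenyl in place of 4-methoxyphenyl on a double-bonded chain carbon bound to a double-bonded chain carbon. For the measured compounds named here, nothing among the measured compounds isolates this swap, so its effect must be guessed. Since compound 1 sits at a limit, a small change in either direction may not register at all, and the aryl group on the other end is not tied to any measured step. Expected is a step of an at least 1.6-fold lower number from compound 1 to compound 4 (0.22 log units; that floor lies within the scatter) that stays close to zero or is modest. Compound 4 is therefore estimated at 60000 nM, within 15000 nM to 200000 nM, with a real chance that only a limit is reported again.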

Compound 4, half-maximal inhibitory concentration: 14500 nM
Beside the measured number, compound 4's estimate is 4.1-fold (0.62 log units) above it, outside the stated range (below it).
By their numbers in this assay, from the lowest: compounds 4 and 2 (each within the scatter of the next); then compound 3. At a limit, above all of these: compound 1.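

In this assay, putting 3,5-difluorophenyl in place of 4-methoxyphenyl on a double-bonded chain carbon bound to a double-bonded chain carbon gives an at least 6.8-fold lower number from compound 1 to compound 4 (0.83 log units; beyond the scatter). Among the compounds shown here, this is the first change in the set that can be read at a single place, and it shows that this end of the chalcone alone, with the rest of the molecule unchanged, can turn a compound with no measured number into one with a measured number. Compound 1 gives > 100000 nM, which is a limit and not a number, so the step sets only a floor and its true size may be larger because of where compound 1 stands: the limit of > 100000 nM in this assay, at which 1 of the 4 values shown sits.

As far as these compounds go, the steps among the other compounds cannot be read, as they differ in more than one place, so it remains open whether the same swap would work on a different chain or end group. From the compounds shown here alone, it also remains open whether the two fluorines matter or whether losing the methoxy is enough, a question that a plain phenyl or a 3,5-dichlorophenyl on the same core could help to settle.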